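The source may report more compounds than this note shows. Statements on the series, on what has been measured and on what is new or still open speak of the compounds shown alone.

On a shared core, the side chain on a double-bonded chain carbon is varied. In a functional assay on CHO cells for inhibition of transient receptor potential cation channel subfamily V member 1 (Homo sapiens) (a higher number here means a weaker inhibitor, a lower number a stronger inhibitor), compound 1 `CC(C)(C)c1ccc(/C(=C/C(=O)Nc2ccc3c(c2)OCCO3)c2ccncc2)cc1` gives 660 nM, while compound 2 `CC(C)C/C(=C\C(=O)Nc1ccc2c(c1)OCCO2)c1ccc(C(C)(C)C)cc1` gives 94 nM. Compound 3 `CC(C)(C)c1ccc(/C(=C/C(=O)Nc2ccc3c(c2)OCCO3)CCC(=O)O)cc1` reaches only a limit of this assay, > 4000 nM. Compound 4 `CN(C)CCC/C(=C\C(=O)Nc1ccc2c(c1)OCCO2)c1ccc(C(C)(C)C)cc1` differs from compound 3 by (dimethylamino)methyl in place of carboxy on a saturated chain carbon, two bonds along the chain from a double-bonded chain carbon. The measured steps that bear on this are an at least 6.0-fold higher number from compound 1 to compound 3 (0.78 log units; beyond the scatter) and an at least 42-fold higher number from compound 2 to compound 3 (1.62 log units; beyond the scatter); each time the carboxy-bearing chain arrived, the number rose beyond the scatter. Taking the carboxy group away again is therefore expected to bring the number back down, toward those of compound 1 and compound 2. Compound 4 is estimated at 400 nM, with a range from 100 nM to 2000 nM, which means an expected step of an at least 10-fold lower number from compound 3 to compound 4 (1.00 log units; beyond the scatter).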

Compound 4, half-maximal inhibitory concentration: > 4000 nM
Compound 4: a limit, no number (the forecaster's own chance of this, stated with the estimate: 10%); middle value at least 10-fold (1.00 log units) away from the limit.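

Replacing carboxy with (dimethylamino)methyl at this position brings no readable recovery: in this assay compound 4 gives > 4000 nM as a limit, not a number. The carboxy group alone therefore does not account for the weak result, since this amine-ending chain also gives an at least 42-fold higher number from compound 2 to compound 4 (1.62 log units; beyond the scatter) and an at least 6.0-fold higher number from compound 1 to compound 4 (0.78 log units; beyond the scatter) in the comparisons with the two stronger compounds. The step between compound 3 and compound 4 cannot be read, since both values are limits: the limit of > 4000 nM in this assay, at which 2 of the 4 values shown sit.

As far as these compounds go, how far past the limit either compound lies remains open, so the two chain ends cannot be ranked. Also open, from the compounds shown here alone, is whether a chain ending in a hydroxyl group, or a plain pentyl chain, would stay close to compound 2.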